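The source may report more compounds than this note shows. Statements on the series, on what has been measured and on what is new or still open speak of the compounds shown alone.

Measured so far:
compound 1, `CCCCCN1CCC(NC(=O)c2cc(Cl)c(N)cc2OC)CC1`, 25.1 nM
compound 2, `COc1cc(N)c(Cl)cc1C(=O)NC1CCN(CCCCCCCCN2CCCCC2)CC1`, 3.16 nM

In a functional assay on HEK293 cells for agonist activity at 5-hydroxytryptamine receptor 4 (Homo sapiens), read by cAMP accumulation (a higher number here means that more compound is needed for the effect, a lower number that less compound is needed), compound 1 gives 25.1 nM, the higher of the two numbers. Compound 3, `COc1cc(N)c(Cl)cc1C(=O)NC1CCN(CCN2CCN(S(C)(=O)=O)CC2)CC1`, differs from compound 1 by 4-(methylsulfonyl)piperazin-1-yl in place of propyl on a saturated chain carbon, two bonds along the chain from an amine nitrogen in a ring. Within the data shown here, the one measured step that bears on it is a 7.9-fold lower number from compound 1 to compound 2 (0.90 log units; beyond the scatter), where 3-(piperidin-1-yl)propyl replaced hydrogen on a saturated chain carbon, five bonds along the chain from an amine nitrogen in a ring. Compound 3 likewise ends its chain in a ring with nitrogen, though the chain is shorter and the ring carries a methylsulfonyl, so a smaller drop is expected, a 2.1-fold lower number from compound 1 to compound 3 (0.32 log units; beyond the scatter). Compound 3 is estimated at 12 nM, within 3 nM to 50 nM.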

Compound 3, half-maximal effective concentration: 20 nM
Compound 3: the middle estimate sits 1.7-fold (0.22 log units) below what was measured; low and high end bracket the measured number.
By their numbers in this assay, from the lowest: compound 2; then compounds 3 and 1 (each within the scatter of the next).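

In this assay, a step of a 1.3-fold lower number from compound 1 to compound 3 (0.10 log units; within the scatter) shows that this place on the chain takes 4-(methylsulfonyl)piperazin-1-yl in place of propyl without a readable shift, although the entering group adds a six-membered non-aromatic ring and 3 hydrogen-bond acceptors. So a ring-bearing end on the chain does not by itself repeat the earlier step of a 7.9-fold lower number from compound 1 to compound 2 (0.90 log units; beyond the scatter). Nothing measured here gives a reason for this result. Still open, as far as these compounds go, is how an acetyl group in place of the methylsulfonyl would read, and how 4-(methylsulfonyl)piperazin-1-yl would read on a longer chain.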